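This account rests on a few compounds, and the source may have more. Where it says the series, first, only, none or still open, it means among the compounds named here.

Of the compounds shown here, three have so far been tested in a functional assay on the whole organism for antagonist activity, with Mus musculus as the target; on this read-out lower numbers stand for an effect already at smaller amounts and higher numbers for an effect only at larger amounts of compound. Compound 1 `CN(C)CC#CCN1CCNC1=O`, which also carries dimethylamino, gives > 100 mg/kg, a limit of the assay and not a number. Going by these compounds, compound 2 `CN1CCN(CC#CCn2ccnc2)C1=O` gives > 100 mg/kg, again only a limit, so its true place on the scale is unknown and it sits with compound 1 at the limit of > 100 mg/kg in this assay, at which 2 of the 3 values shown sit. Compound 3 `Cc1cncn1CC#CCN1CCN(C)C1=O` gives a true number, 14 mg/kg.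

Going by the values given here, the one measured step, an at least 7.1-fold lower number from compound 2 to compound 3 (0.85 log units; beyond the scatter), is methyl in place of hydrogen on an aromatic carbon; it lies beyond the scatter and starts from a limit. The change now followed leads to compound 4 `CN(C)CC#CCN1CCN(C)C1=O`: dimethylamino in place of 1H-imidazol-1-yl on a saturated chain carbon bound to a triple-bonded carbon. Among the compounds with values here, no measured step covers this exchange, so only a modest lowering in this assay is expected, of about the size of the step to compound 3, and another limit remains quite possible. The expected step is an at least 2.0-fold lower number from compound 2 to compound 4 (0.30 log units; that floor lies within the scatter). Compound 4 is estimated at 50 mg/kg, with an expected range of 12 mg/kg to 200 mg/kg.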

Compound 4, dose for half-maximal effect: > 10 mg/kg
Compound 4: only a limit was reported; the forecaster's own chance of this, stated with the estimate: 50%; the middle value does not contradict the limit.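

Compound 1, compound 2 and compound 4 each gave only a limit and not a number, so the steps from compound 2 and from compound 1 to compound 4 cannot be read. Where compound 4 truly stands in this assay stays open.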